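Trifluoromethyl replaces bromo on the aryl of compound 2

The source may hold more compounds than are shown below. What is called first, only, known or untested is meant among the compounds shown, and "the series" means these compounds.

Compound 1 `CC(C)(C)C1=NN(c2ccc(F)cc2)C(c2ccc(O)cc2)C1` was tested in an assay on isolated protein for inhibition of protein kinase C zeta type (Homo sapiens), with a stated time of 4 min, tested at 62.5 uM (on this read-out lower numbers stand for less inhibition and higher numbers for more inhibition at the one concentration tested (going by the name of the read-out)), and gave 95.5%. Among the compounds with values here, compound 2 `CC(C)(C)C1=NN(c2ccc(Br)cc2)C(c2ccc(O)cc2)C1` gave 93.2% in this assay; the step of a number 2.3 percentage points lower from compound 1 to compound 2 (within the scatter) shows that the two numbers lie within the usual scatter of each other, so compound 2 stands level with the only other measured compound. Compound 3 `CC(C)(C)C1=NN(c2ccc(C(F)(F)F)cc2)C(c2ccc(O)cc2)C1` carries the change (trifluoromethyl in place of bromo on an aromatic carbon). Within the data shown here, the single measured step that bears on this change is the exchange of one halogen for another on the same aromatic carbon, a number 2.3 percentage points lower from compound 1 to compound 2 (within the scatter), which did not move the read-out beyond the scatter. On that basis the expected step is a number 1.2 percentage points lower from compound 2 to compound 3 (within the scatter), a change of no real size in this assay. Compound 3 is accordingly estimated to give 92% in this assay, with a likely range from 80% to 100%.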

Compound 3, a percentage reported as inhibition, at one concentration (the size of the read-out at that concentration, not a potency): 94.2%
The estimate for compound 3 lay 2.2 percentage points below the measured number; the range from low to high includes it.
By their numbers in this assay, from the lowest: compounds 2, 3 and 1 (each within the scatter of the next).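

In this assay, replacing the single bromine atom with the four heavy atoms of trifluoromethyl gives a number 1 percentage points higher from compound 2 to compound 3 (within the scatter), and the comparison with the fluoro compound gives a number 1.3 percentage points lower from compound 1 to compound 3 (within the scatter). Until now only an exchange of one halogen for another had been seen on this aromatic carbon, para to a large group; these steps extend the level read-out to a larger group that is not a single halogen, so fluoro, bromo and trifluoromethyl cannot be told apart here at the one concentration tested. Nothing measured alongside these numbers accounts for this level result.

What the compounds shown leave open is whether a group of another kind at this place, such as an amine or a carboxylic acid, would also keep the number level. They also do not show whether these three groups would differ in a potency measurement across several concentrations.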